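An Amide Chain Added to Compound 1

A few compounds are considered here, and "the series" means these few. Any claim that something is new, unique, unknown or untested is made for them only; others in the source may bear on it.

In a functional assay on Huh-7 cells (Homo sapiens) for antiproliferative activity, read by CCK-8 assay, with a stated time of 72 h (a lower number here means a stronger inhibitor of growth, a higher number a weaker inhibitor of growth), compound 1 `CC[C@@H]1C(=O)N(C)c2cnc(-n3ccc4ccccc43)nc2N1C1CCCC1` gives 4690 nM and compound 2 `CCCNC(=O)c1ccc2c(ccn2-c2ncc3c(n2)N(c2ccn(C)n2)C(CC)C(=O)N3C)c1` gives 7280 nM, two numbers within the scatter of each other. Among the compounds with values here, compound 3 `CCC1C(=O)N(C)c2cnc(Nc3ccc(S(N)(=O)=O)cc3)nc2N1c1ccn(C)n1` is recorded as "not active" (no number reported), so compound 1 stands as one of only two compounds with a number. Compound 4 `CC[C@@H]1C(=O)N(C)c2cnc(-n3ccc4cc(C(=O)NCC(C)C)ccc43)nc2N1C1CCCC1` keeps the core of compound 1 and takes isobutylcarbamoyl in place of hydrogen on an aromatic carbon, (isobutylcarbamoyl in place of hydrogen on an aromatic carbon). Compound 2 also carries an amide side chain and gives 7280 nM, so no step beyond the scatter is expected in this assay, in either direction. The estimated step is a 1.2-fold lower number from compound 1 to compound 4 (0.07 log units; within the scatter). For compound 4 a value of 4000 nM is expected, within a range from 1200 nM to 12000 nM.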

Compound 4, concentration for 50% growth inhibition: "not active" (no number reported)
Compound 4 has no reported number here; there is nothing to compare the estimate with.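

In this assay, within the data shown here, compound 4 is recorded as "not active" (no number reported) and no step from compound 1 to compound 4 can be read; no measured evidence bears on this result. The compounds shown leave open whether isobutylcarbamoyl in place of hydrogen changes growth inhibition at all.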